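Propanoyl to Propylcarbonyl on Two Related Amide Cores

The compounds below may be only part of what the source reports. "The series", "measured", "known", "first", "only" and "open" are said of these compounds alone.

Compound 1 `CCC(=O)NCc1cc(OC)ccc1F` carries a propanoyl amide on a short benzylic linker. In an assay on isolated protein for agonist activity at melatonin receptor type 1C (Xenopus laevis), read by spectrophotometry (on this read-out lower numbers stand for smaller maximal responses and higher numbers for larger maximal responses), compound 1 reaches 69%. Compound 2 `CCCC(=O)NCc1cc(OC)ccc1F` differs from it by methyl in place of hydrogen on a saturated chain carbon, two bonds along the chain from a carbonyl carbon. In this assay compound 2 reaches 43%, so the step of a number 26 percentage points lower from compound 1 to compound 2 (beyond the scatter) runs downward.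

Compound 3 `CCC(=O)NCCCc1cc(OC)ccc1F` keeps the propanoyl amide but links it to the aromatic core through a longer saturated chain. The difference between the core of compound 1 and the core of compound 3 is not broken down here. In this assay compound 3 reaches 100%, the highest of the three measured numbers, and its steps to compound 1 and to compound 2 both lie beyond the scatter.

Compound 4 `CCCC(=O)NCCCc1cc(OC)ccc1F` is not yet measured. It differs from compound 3 by methyl in place of hydrogen on a saturated chain carbon, two bonds along the chain from a carbonyl carbon. This is the same change as that from compound 1 to compound 2, made on the longer-linked core. Because the measured step of a number 26 percentage points lower from compound 1 to compound 2 (beyond the scatter) was a modest fall, a downward step of similar size is expected here, a number 26 percentage points lower from compound 3 to compound 4 (beyond the scatter). Only one earlier example of this change exists among these compounds, so the expectation rests on a single precedent. On that basis compound 4 is expected to reach about 74% in this assay, with a plausible span from 55% to 92%.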

Compound 4, largest response reached (reported as efficacy), in percent of the reference or control that the assay uses: 100%
Compound 4: the middle estimate sits 26 percentage points below what was measured; measured number outside the range, above it.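

In this assay the same methyl in place of hydrogen, on a saturated chain carbon two bonds along the chain from a carbonyl carbon, gives no change at the digits printed from compound 3 to compound 4 (within the scatter), and so it does not carry over from one core to the other at the same size: the same change on two cores in this assay, a number 26 percentage points lower (beyond the scatter) from compound 1 to compound 2 and no change at the digits printed (within the scatter) from compound 3 to compound 4, 26 percentage points apart, beyond the scatter of two such steps Within these four compounds, then, the drop seen on the core of compound 1 is absent on the core of compound 3, and the change cannot be treated as a fixed increment that holds whatever core it is made on. Within the data shown here, this comparison rests on only two pairs, and it does not show why the two cores part or how the same change would read on any further core.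

The compounds shown leave open how a longer chain on the carbonyl side, such as a pentanoyl amide, or a branched one, such as an isobutyryl amide, would read on either core. They also leave open whether the split between the two cores would persist with a chlorine in place of the fluorine or a hydroxyl in place of the methoxy group.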